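The source may report more compounds than this note shows. Statements on the series, on what has been measured and on what is new or still open speak of the compounds shown alone.

Compound 1 `CN(C)CCCOc1ccccc1/C=C/c1ccccc1` gives 14.2% in a functional assay on the whole organism with Mus musculus as the target, in the maximal electroshock model, at a dose of 50 mg/kg by the oral route; on this read-out lower numbers stand for less inhibition and higher numbers for more inhibition at the one dose given (going by the name of the read-out).
Compound 2 `CN(C)CCCCOc1ccccc1/C=C/c1ccccc1Cl` gives 14.3% in this assay.
Compound 3 `C(=C/c1ccccc1OCCCCN1CCCCC1)\c1ccccc1` gives 42.9% in this assay.

Three measured compounds share a core and differ in the amine at the end of the chain. Compound 3 has the highest number of the three in this assay, with the two others, compound 1 and compound 2, each sitting well below it, both gaps beyond the scatter. For the measured compounds named here, the one step that can be traced in a single change, a number 28.7 percentage points higher from compound 1 to compound 3 (beyond the scatter), shows that exchanging the amine group at the end of the chain can move the read-out by a sizeable amount.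

Compound 4 `CCN1CCN(CCCCOc2ccccc2/C=C/c2ccccc2)CC1` has not been measured. It differs from compound 3 in one place: 4-ethylpiperazin-1-yl in place of piperidin-1-yl on a saturated chain carbon, four bonds along the chain from an oxygen on an aromatic ring. Going by the values given here, no measured pair isolates this particular exchange of one ring amine for another, so the step from compound 1 to compound 3 only tells that such a change can matter, not in which direction. With no directional evidence, the expected step of a number 7.9 percentage points lower from compound 3 to compound 4 (within the scatter) is small and uncertain, and compound 4 is estimated at 35%, within a range from 10% to 65%.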

Compound 4, a percentage reported as inhibition, in the whole organism at one dose (the size of the read-out at that dose, not a potency): 33.3%
Beside the measured number, compound 4's estimate is 1.7 percentage points above it; low and high end bracket the measured number.
By their numbers in this assay, from the lowest: compounds 1 and 2 (each within the scatter of the next); then compounds 4 and 3 (each within the scatter of the next).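

In this assay, 4-ethylpiperazin-1-yl in place of piperidin-1-yl, four bonds along the chain from an oxygen on an aromatic ring, gives a number 9.6 percentage points lower from compound 3 to compound 4 (within the scatter) and so stays within the scatter: at this position, the two ring amines cannot be told apart. The dimethylamino end group now has a second comparison, a number 19.1 percentage points higher from compound 1 to compound 4 (beyond the scatter), which is beyond the scatter, so a clear step from dimethylamino is seen with two different ring amines rather than with piperidin-1-yl alone. No measurement shown gives a reason for these steps.

Going by these compounds, whether a morpholine, a pyrrolidine or a piperazine with a free ring nitrogen at the chain end would fit with these two ring amines remains open. So does what a longer chain would do to the read-out.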